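Notes on a chloro to methyl swap in the series

The source may report more compounds than this note shows. Statements on the series, on what has been measured and on what is new or still open speak of the compounds shown alone.

Measured values in an ADME assay on MT4 cells (Homo sapiens) for cytotoxicity, read by MTT assay, with a stated time of 96 h (a higher number here means that more compound is tolerated, a lower number that less compound is tolerated), are as follows.
- compound 1 `NS(=O)(=O)c1ccc(N2N=C(c3ccc(Oc4ccccc4)cc3)CC2c2cccc(F)c2)cc1` gives 25000 nM
- compound 2 `Cc1ccc(C2CC(c3ccc(Oc4ccccc4)cc3)=NN2c2ccc(S(N)(=O)=O)cc2)cc1` gives 7200 nM
- compound 3 `NS(=O)(=O)c1ccc(N2N=C(c3ccc(Oc4ccccc4)cc3)CC2c2ccccc2Cl)cc1` gives 40000 nM

Compound 3 stands with compound 1 at the upper end of these numbers, and a 1.6-fold higher number from compound 1 to compound 3 (0.20 log units; within the scatter) keeps the pair within the scatter of each other. Compound 2 stands apart, with a 5.6-fold higher number from compound 2 to compound 3 (0.74 log units; beyond the scatter) as the widest gap in the set.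

Next comes compound 4 `Cc1ccccc1C1CC(c2ccc(Oc3ccccc3)cc2)=NN1c1ccc(S(N)(=O)=O)cc1` with the change methyl in place of chloro on an aromatic carbon from compound 3, read one bond further out as 2-chlorophenyl to 2-methylphenyl. Among the measured compounds shown here, no measured pair makes this swap at a single place. For the measured compounds named here, the nearest evidence is compound 2, the only measured compound with a methyl, but a 3.5-fold lower number from compound 1 to compound 2 (0.54 log units; beyond the scatter) and a 5.6-fold higher number from compound 2 to compound 3 (0.74 log units; beyond the scatter) each change the place of the substituent as well as the group. The step of a 1.6-fold higher number from compound 1 to compound 3 (0.20 log units; within the scatter) shows that an exchange of aryl groups can also stay inside the scatter. A small downward step in this assay is therefore expected, near the edge of the scatter. The expected step is a 2.0-fold lower number from compound 3 to compound 4 (0.30 log units; within the scatter) by this estimate. For compound 4 the estimated value is 20000 nM with an expected range from 8000 nM to 45000 nM in this assay.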

Compound 4, half-maximal cytotoxic concentration: 36000 nM
Compound 4: the middle estimate sits 1.8-fold (0.26 log units) below what was measured; measured number inside the range.
By their numbers in this assay, from the lowest: compound 2; then compounds 1, 4 and 3 (each within the scatter of the next).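

In this assay, the direct swap of methyl in place of chloro on an aromatic carbon, ortho to a large group, gives a 1.1-fold lower number from compound 3 to compound 4 (0.05 log units; within the scatter) and so gives no reading that separates the two groups at this place, which the earlier cross-position comparisons could not show. Among the aryl groups, compounds 1, 3 and 4 all lie within the scatter of one another, as a 1.4-fold higher number from compound 1 to compound 4 (0.16 log units; within the scatter) adds, while compound 2 goes against this grouping: a 5.0-fold higher number from compound 2 to compound 4 (0.70 log units; beyond the scatter) shows that 2-methylphenyl and 4-methylphenyl do not read alike, so the presence of a methyl alone does not set the lower number of compound 2. No measurement on hand gives a reason for either the match or the gap.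

A 4-chlorophenyl partner for compound 2 would show whether its lower number belongs to that place or to the methyl group there. Also open, as far as these compounds go, is whether the level shared by compounds 1, 3 and 4 would hold with a methoxy, an amine or a carboxylic acid on the same ring.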